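This account rests on a few compounds, and the source may have more. Where it says the series, first, only, none or still open, it means among the compounds named here.

Measured so far:
compound 1 `Cn1cncc1CN1CC(N(CC2CCN(C(=O)CNC(=O)OC(C)(C)C)CC2)S(=O)(=O)c2ccccn2)Cc2cc(C#N)ccc21`; in an ADME assay on Caco-2 cells (Homo sapiens) for permeability, in the apical to basolateral direction (on this read-out lower numbers stand for lower permeability and higher numbers for higher permeability), compound 1 gives 0.5 10^-6 cm/s.
compound 2 `CCC(=O)N1CCC(CN(C2Cc3cc(C#N)ccc3N(Cc3cncn3C)C2)S(=O)(=O)c2ccccn2)CC1`; in this assay compound 2 gives 0.5 10^-6 cm/s.
compound 3 `Cn1cncc1CN1CC(N(CC2CCN(S(C)(=O)=O)CC2)S(=O)(=O)c2ccccn2)Cc2cc(C#N)ccc21`; in this assay compound 3 gives 0.1 10^-6 cm/s.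

Compound 3 holds the lowest number of the three, while compounds 1 and 2 sit at one value within the scatter (no change at the digits printed from compound 1 to compound 2 (within the scatter)). Both steps that reach compound 3 change the group on the amine nitrogen in the ring: a 5.0-fold lower number from compound 1 to compound 3 (0.70 log units; beyond the scatter) and a 5.0-fold lower number from compound 2 to compound 3 (0.70 log units; beyond the scatter).

Compound 4 `Cn1cncc1CN1CC(N(CCn2cccc2)S(=O)(=O)c2ccccn2)Cc2cc(C#N)ccc21` is not yet measured. Its difference from compound 3: (1H-pyrrol-1-yl)methyl in place of 1-(methylsulfonyl)piperidin-4-yl on a saturated chain carbon bound to a sulfonamide nitrogen. Here the ring that carried the methylsulfonyl leaves altogether, so the two measured steps onto that ring nitrogen bear on it only indirectly; both show the methylsulfonyl compound 3 as the lowest, and a number above compound 3 is therefore expected, with a step estimated at a 15-fold higher number from compound 3 to compound 4 (1.18 log units; beyond the scatter). For compound 4 the estimate in this assay is 1.5 10^-6 cm/s, range 0.4 10^-6 cm/s to 5 10^-6 cm/s.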

Compound 4, apparent permeability: 12.4 10^-6 cm/s
Estimate against measurement, compound 4: 8.3-fold (0.92 log units) below; measured number above the stated range.
By their numbers in this assay, from the lowest: compound 3; then compounds 1 and 2 (each within the scatter of the next); then compound 4.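

In this assay the position tolerates far more than the earlier changes on the ring nitrogen suggested: (1H-pyrrol-1-yl)methyl in place of 1-(methylsulfonyl)piperidin-4-yl gives a 120-fold higher number from compound 3 to compound 4 (2.09 log units; beyond the scatter) and in place of 1-propanoylpiperidin-4-yl gives a 25-fold higher number from compound 2 to compound 4 (1.39 log units; beyond the scatter) on the same saturated chain carbon. The rise therefore does not depend on methylsulfonyl as the starting point, since it also appears from the propanoyl compound. Nothing measured here accounts for the size of these steps.

Each step replaces the whole non-aromatic ring with a smaller aromatic one, so the contributions of ring type and ring size stay unseparated. A phenyl ring, a cyclohexyl ring or a plain alkyl chain at this place would help to separate them.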